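The source may hold more compounds than are shown below. What is called first, only, known or untested is meant among the compounds shown, and "the series" means these compounds.

Within the data shown here, in a functional assay on the whole organism (strain Sprague-Dawley albino) with Rattus norvegicus as the target (on this read-out higher numbers stand for an effect only at larger amounts of compound and lower numbers for an effect already at smaller amounts), compound 1 `CCC(COC(N)=O)C(C)C` gives 35 mg/kg as the only plain number in this small set. Compound 2 `CCCC(CCC)COC(N)=O` gives > 125 mg/kg and that value is a limit of the assay, not a number. Compound 3 `CCC(C)C(CC)COC(N)=O` has not yet been measured and keeps the core of compound 1 with a single change: methyl in place of hydrogen on a saturated chain carbon, four bonds along the chain from an oxygen next to a carbonyl group is how it reads, methyl in place of hydrogen on a saturated chain carbon, four bonds along the chain from an oxygen next to a carbonyl group, which turns isopropyl into sec-butyl. Among the measured compounds shown here, no measured pair shows what such a change does in this assay so the expectation rests on very little. For the measured compounds named here, the one hint toward larger doses is compound 2 with its limit of > 125 mg/kg as the only other reading. A modest move toward larger doses is expected, about the size of the usual scatter, and the estimated change is a 1.7-fold higher number from compound 1 to compound 3 (0.23 log units; within the scatter) in that direction. Compound 3 is therefore estimated at 60 mg/kg with an expected range from 25 mg/kg to 140 mg/kg in repeated measurements.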

Compound 3, dose for half-maximal effect: 68 mg/kg
Beside the measured number, compound 3's estimate is 1.1-fold (0.05 log units) below it, within the range that was stated.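

Among these compounds, the first step that can be read at this position comes from this assay: a 1.9-fold higher number from compound 1 to compound 3 (0.29 log units; within the scatter). Methyl in place of hydrogen on a saturated chain carbon, four bonds along the chain from an oxygen next to a carbonyl group, turns isopropyl into sec-butyl, and on this single pair the change cannot be told apart from repeat measurements of the same compound, so the position tolerates this added carbon without a clear shift in the dose read-out. Compound 3 also gives a plain number, which allows this comparison, whereas compound 2 offers no such reading and its value is a limit of the assay: the limit of > 125 mg/kg in this assay, at which 1 of the 3 values shown sits.

The compounds shown leave open whether a larger group at this place, such as a longer chain like n-butyl, or a hydroxyl group, would move the dose beyond the usual scatter. From the compounds shown here alone, one pair also gives no trend, and it remains open whether the same methyl would give a similar step on a core other than that of compound 1.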